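From butyl to 4-fluorophenyl on an aromatic nitrogen

The source may report more compounds than this note shows. Statements on the series, on what has been measured and on what is new or still open speak of the compounds shown alone.

Measured in a functional assay on MDA-MB-231 cells (Homo sapiens) for antiproliferative activity, read by MTT assay, with a stated time of 72 h; on this read-out higher numbers stand for weaker inhibition and lower numbers for stronger inhibition:
- compound 1 `CCCCn1ccnc1-c1cc(OC)c(OC)c(OC)c1` gives 70400 nM
- compound 2 `COc1cc(-c2nccn2S(=O)(=O)c2ccc(C)cc2)cc(OC)c1OC` gives > 100000 nM (a limit)
- compound 3 `COc1cc(OC)cc(-n2ccnc2-c2cc(OC)c(OC)c(OC)c2)c1` gives 45200 nM

Within the data shown here, compound 3 at 45200 nM and compound 1 at 70400 nM lie within the usual scatter of each other, so compound 1 stands level with the only other number available. Compound 2 reports > 100000 nM, which is a limit of the assay and not a number.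

Compound 4 `COc1cc(-c2nccn2-c2ccc(F)cc2)cc(OC)c1OC` has yet to be measured. It differs from compound 1 by 4-fluorophenyl in place of butyl on an aromatic nitrogen of the five-membered ring (4-fluorophenyl in place of butyl on an aromatic nitrogen). Among the measured compounds shown here, no measured pair here isolates such a change. With compound 1 at 70400 nM as the starting point, no step beyond the scatter is expected in this assay. The expected size of the change is a 1.6-fold lower number from compound 1 to compound 4 (0.19 log units; within the scatter), and this remains an estimate. Compound 4 is estimated at 45000 nM, with an expected range from 12000 nM to 100000 nM.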

Compound 4, half-maximal inhibitory concentration: 38400 nM
Beside the measured number, compound 4's estimate is 1.2-fold (0.07 log units) above it; measured number inside the range.
By their numbers in this assay, from the lowest: compounds 4, 3 and 1 (each within the scatter of the next). At a limit, above all of these: compound 2.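

In this assay, among these compounds, 4-fluorophenyl in place of butyl on the aromatic nitrogen gives a 1.8-fold lower number from compound 1 to compound 4 (0.26 log units; within the scatter) as the first step at this position that can be read. An aromatic ring can therefore replace the open chain here without a shift beyond the scatter, so this one change neither gains nor loses measurable antiproliferative activity. Nothing in the data at hand explains why the two groups read alike.

On these data alone, whether a chain ending in an amine or a carboxylic acid on this nitrogen would move the number beyond the scatter stays open. So does the part played by the fluorine, which a plain phenyl at the same place would separate from that of the ring itself.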